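This account rests on a few compounds, and the source may have more. Where it says the series, first, only, none or still open, it means among the compounds named here.

Compound 3 `Oc1ccccc1CNc1ccc(-c2ccc(-c3ccccc3)cc2)cc1` is recorded in a functional assay on Jurkat cells (Homo sapiens) for activation, with a stated time of 24 h (on this read-out higher numbers stand for an effect only at larger amounts of compound and lower numbers for an effect already at smaller amounts), as "not active" (no number reported), with no number reported, so its standing cannot be placed against the other compounds. Compound 4 `Oc1ccccc1CNc1ccc(-c2ccc(C(F)(F)F)cc2)cc1` differs from it by trifluoromethyl in place of phenyl on an aromatic carbon. Within the data shown here, no measured step covers this change directly. The nearest comparison is the pair of compound 1 `Oc1ccccc1CNc1ccc(-c2ccc(F)cc2)cc1` and compound 2 `Oc1ccccc1CNc1ccc(-c2ccc(Cl)cc2)cc1`, which carry fluoro and chloro at the same position; in this assay compound 1 gives 3860 nM and compound 2 gives 2390 nM, and the step of a 1.6-fold lower number from compound 1 to compound 2 (0.21 log units; within the scatter) lies within the scatter. Since compound 4 resembles these two rather than compound 3, it is expected to fall near them, and its value in this assay is estimated at 2500 nM, within a range of 900 nM to 8000 nM.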

Compound 4, half-maximal effective concentration: "not active" (no number reported)
Nothing numeric was reported for compound 4, and the estimate cannot be compared.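

Among these compounds, compound 3 and compound 4 are both recorded as not active, without a number, so no step between them can be read. The compounds shown leave open whether phenyl and trifluoromethyl differ at this place at all, and no evidence bears on this result.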